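The source may report more compounds than this note shows. Statements on the series, on what has been measured and on what is new or still open speak of the compounds shown alone.

Of the compounds shown here, three have so far been tested in a functional assay on the whole organism (strain albino) for inhibition, with Rattus norvegicus as the target, read by paw edema, with a stated time of 3 h, at a dose of 0.28 mmol/kg by the oral route; a lower number here means less inhibition, a higher number more inhibition at the dose given (going by the name of the read-out). Compound 1 `CCn1c(SCC(=O)c2ccccc2)nnc1-c1ccc(OC)cc1` gives 67% there. Compound 2 `CCn1c(SCC(=O)c2ccccc2)nnc1-c1ccccc1` is the closest relative of compound 1 among the three, and in this assay compound 2 gives 61%. The structural difference between them is hydrogen in place of methoxy on an aromatic carbon, and the corresponding step is a number 6 percentage points lower from compound 1 to compound 2 (within the scatter). Compound 3 `CCn1c(SC/C(=N/O)c2ccccc2)nnc1-c1cc(OC)c(OC)c(OC)c1` gives 69% in this assay; the difference between the core of compound 3 and the core of compound 1 is not broken down here, because the two differ in more than one place.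

Compound 4 `CCn1c(SC/C(=N/O)c2ccccc2)nnc1-c1ccc(OC)c(OC)c1` has not yet been measured. It differs from compound 3 by hydrogen in place of methoxy on an aromatic carbon. Going by the values given here, this is the same kind of change as the one from compound 1 to compound 2, but not the same: in compound 1 the methoxy that leaves sits para to a large group, whereas in compound 3 it sits ortho to a methoxy group, meta to a large group and meta to a methoxy group.

Among the compounds with values here, the only guide is the earlier step, which was within the scatter. The step from compound 3 to compound 4 is therefore expected to be small as well, a number 5 percentage points lower from compound 3 to compound 4 (within the scatter), resting on the observation that a number 6 percentage points lower from compound 1 to compound 2 (within the scatter). For compound 4 the estimate in this assay is 64%. The expected range for compound 4 runs from 52% to 76%.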

Compound 4, a percentage reported as inhibition, in the whole organism at one dose (the size of the read-out at that dose, not a potency): 71%
Beside the measured number, compound 4's estimate is 7 percentage points below it, within the range that was stated.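

In this assay, putting hydrogen in place of a methoxy group gives a number 2 percentage points higher from compound 3 to compound 4 (within the scatter), and the two cases on which this change can be read do not differ by more than repeated measurements would: the same change on two cores in this assay, a number 6 percentage points lower (within the scatter) from compound 1 to compound 2 and a number 2 percentage points higher (within the scatter) from compound 3 to compound 4, 8 percentage points apart, within the scatter of two such steps. So, as far as these two pairs go, the change carries over from the core of compound 1 to the core of compound 3 in a modest sense: on both cores the step stays inside the usual scatter. Going by these compounds alone, this does not prove that the methoxy group is without effect or that the two cores respond alike, since a small real effect could lie hidden in the scatter, only two pairs are available, each was read at a single dose and a single time, and in the second pair the methoxy group that leaves sits ortho to a methoxy group.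

The compounds shown leave open whether a different group on that aromatic ring, such as a chlorine atom, an amine or a carboxylic acid, would move the paw edema read-out beyond the scatter. They also leave open what a longer chain in place of the ethyl group on the shared core would do.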